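The compounds below may be only part of what the source reports. "The series", "measured", "known", "first", "only" and "open" are said of these compounds alone.

Compound 1 `CO[C@@H]1[C@@H](O)[C@@H](O)[C@H]2O[C@]1(C)n1c3ccccc3c3c4c(c5c6ccccc6n2c5c31)C(=O)NC4` and compound 2 `CO[C@@H]1[C@H](NC(=O)C(=O)c2c[nH]c3ccccc23)C[C@H]2O[C@]1(C)n1c3ccccc3c3c4c(c5c6ccccc6n2c5c31)C(=O)NC4` share one large core and differ in the group hanging from a sugar-like ring. In an assay on isolated protein for inhibition of protein kinase C theta type (Homo sapiens), read by HTRF (on this read-out higher numbers stand for weaker inhibition and lower numbers for stronger inhibition), compound 1 gives 1010 nM. In the same assay compound 2 gives 1790 nM; this is the higher of the two numbers, but the gap to compound 1 lies within the scatter of repeated measurements, so the two compounds cannot be told apart on these data.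

Compound 3 `CO[C@@H]1[C@H](NC(C)=O)C[C@H]2O[C@]1(C)n1c3ccccc3c3c4c(c5c6ccccc6n2c5c31)C(=O)NC4` has not yet been measured. It arises from compound 2 by a single change: methyl in place of (1H-indol-3-yl)carbonyl on a carbonyl carbon. This trims the amide down to a small acetyl group. Within the data shown here, no measured pair shows the effect of such a change here, so the expectation rests only on the two values above. The step from compound 2 to compound 3 is expected to be a 1.2-fold lower number from compound 2 to compound 3 (0.08 log units; within the scatter), with no clear direction. For compound 3 the estimated value in this assay is 1500 nM, with a plausible range from 400 nM to 6000 nM.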

Compound 3, half-maximal inhibitory concentration: 38 nM
The estimate for compound 3 lay 39-fold (1.60 log units) above the measured number; measured number outside the range, below it.
By their numbers in this assay, from the lowest: compound 3; then compounds 1 and 2 (each within the scatter of the next).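

In this assay, replacing (1H-indol-3-yl)carbonyl with methyl on a carbonyl carbon gives a 47-fold lower number from compound 2 to compound 3 (1.67 log units; beyond the scatter), so this position is far from indifferent to what it carries. The two earlier values gave no hint of this, since those compounds differ in more than one place and sit within the scatter of each other. Here the group that leaves has 11 heavy atoms and two rings, the group that enters is a single carbon, and nothing shown explains why the number falls so far.

With only these two groups compared at this position, a single step cannot show a trend. An ethyl group, a longer chain, a phenyl ring or an amine on the same carbonyl carbon could land near either compound 2 or compound 3, and the data do not say which.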